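Ester variation on a quinolinone core: estimating a cinnamate

This account rests on a few compounds, and the source may have more. Where it says the series, first, only, none or still open, it means among the compounds named here.

Measured compounds:
Compound 1, `CCC(=O)OCCc1c(-c2ccccc2Cl)c2cc(Cl)ccc2[nH]c1=O`: 95000 nM
Compound 2, `COCC(=O)OCCc1c(-c2ccccc2Cl)c2cc(Cl)ccc2[nH]c1=O`: 74000 nM
Compound 3, `O=C(OCCc1c(-c2ccccc2Cl)c2cc(Cl)ccc2[nH]c1=O)C1CCCC1`: 46000 nM

Three esters of a shared core have been tested in an ADME assay on HepG2 2.2.15 cells (Homo sapiens) for cytotoxicity; on this read-out lower numbers stand for higher toxicity in this test and higher numbers for lower toxicity in this test. Compound 2 holds the second highest number of the three; its nearest neighbour is compound 1 with a 1.3-fold lower number from compound 1 to compound 2 (0.11 log units; within the scatter), and its furthest is compound 3 with a 1.6-fold lower number from compound 2 to compound 3 (0.21 log units; within the scatter), so neither gap separates it from the others. Within the data shown here, the only step that clears the scatter is a 2.1-fold lower number from compound 1 to compound 3 (0.31 log units; beyond the scatter), a modest move toward greater toxicity when the ethyl group is enlarged.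

Compound 4, `COc1ccc(/C=C/C(=O)OCCc2c(-c3ccccc3Cl)c3cc(Cl)ccc3[nH]c2=O)cc1OC`, has not yet been measured in this assay. It differs from compound 2 as follows: 2-(3,4-dimethoxyphenyl)ethenyl in place of methoxymethyl on a carbonyl carbon. The change enlarges the acyl part far more than the step to compound 3 did. The one enlargement on record, a 2.1-fold lower number from compound 1 to compound 3 (0.31 log units; beyond the scatter), lowered the number modestly; the step from compound 2 to compound 3 stayed within the scatter. She therefore expects a downward step in this assay, somewhat beyond the scatter, amounting to a 2.5-fold lower number from compound 2 to compound 4 (0.39 log units; beyond the scatter). Her estimate for compound 4 is 30000 nM, with a range from 10000 nM to 90000 nM.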

Compound 4, half-maximal cytotoxic concentration: > 1200000 nM
Compound 4 was reported as a limit; the forecaster's own chance of this, stated with the estimate: 15%; middle value at least 40-fold (1.60 log units) from the limit.
By their numbers in this assay, from the lowest: compounds 3, 2 and 1 (each within the scatter of the next, the first and the last beyond it). At a limit, above all of these: compound 4.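

The reading for compound 4 in this assay is a limit of the assay and not a number: the limit of > 1200000 nM in this assay, at which 1 of the 4 values shown sits. It shows that the group on this carbonyl carbon can move the number strongly upward, for the 2-(3,4-dimethoxyphenyl)ethenyl group gives an at least 16-fold higher number from compound 2 to compound 4 (1.20 log units; beyond the scatter), an at least 26-fold higher number from compound 3 to compound 4 (1.41 log units; beyond the scatter) and an at least 12-fold higher number from compound 1 to compound 4 (1.10 log units; beyond the scatter), all three large and beyond the scatter. The earlier enlargement, a 2.1-fold lower number from compound 1 to compound 3 (0.31 log units; beyond the scatter), had pointed the other way, so among these four compounds a larger acyl group does not go with a lower number: compound 3 fits such a trend, and compound 4 goes against it.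

The compounds shown leave open which part of the entering group goes with this step, whether the aromatic ring, the double bond or the two methoxy groups, and a plain 2-phenylethenyl group or a saturated 2-phenylethyl group would begin to separate these parts. They also leave open how an aromatic acyl group carrying an amine or a carboxylic acid would read in this assay.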